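Bromo-to-hydroxy swap in a triazole series on K562

This account rests on a few compounds, and the source may have more. Where it says the series, first, only, none or still open, it means among the compounds named here.

Measured compounds:
- compound 1 `COc1ccc(-c2cn(-c3cc(OC)c(OC)c(OC)c3)nn2)cc1Br`: > 10000 nM
- compound 2 `COc1ccc(-c2cn(-c3cc(OC)c(OC)c(OC)c3)nn2)cc1O`: > 10000 nM
- compound 3 `COc1ccc(Cn2cc(-c3cc(OC)c(OC)c(OC)c3)nn2)cc1Br`: > 10000 nM

In a functional assay on K562 cells (Homo sapiens) for cytotoxicity, read by MTT assay, with a stated time of 5 days (a higher number here means a weaker inhibitor, a lower number a stronger inhibitor), compound 1 gives only a limit, > 10000 nM. Compound 2 likewise gives only a limit, > 10000 nM. Compound 3 too gives only a limit, > 10000 nM. The change from compound 1 to compound 2 is hydroxy in place of bromo on an aromatic carbon, and its step is a step that the two limits leave unreadable from compound 1 to compound 2, so its size cannot be read. The difference between the cores of compound 1 and compound 3 is not broken down here.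

Compound 4 `COc1ccc(Cn2cc(-c3cc(OC)c(OC)c(OC)c3)nn2)cc1O` is not yet measured. It differs from compound 3 by hydroxy in place of bromo on an aromatic carbon, the same change as that from compound 1 to compound 2. With compound 3 at a limit and with the limit of > 10000 nM in this assay, at which 3 of the 3 values shown sit, no readable step is available to carry over. The expected step that the limit leaves unreadable from compound 3 to compound 4 is therefore small, and compound 4 is expected to remain near the limit. The estimate for compound 4 in this assay is 15000 nM, with a range from 5000 nM to 50000 nM.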

Compound 4, half-maximal inhibitory concentration: > 10000 nM
Compound 4 was reported as a limit (the forecaster's own chance of this, stated with the estimate: 80%); the middle value does not contradict the limit.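

No step can be read between compound 3 and compound 4, as both are reported only as limits in this assay: the limit of > 10000 nM in this assay, at which 4 of the 4 values shown sit.

The compounds shown leave open whether hydroxy in place of bromo on an aromatic carbon changes potency in either core, and how the core of compound 1 compares with the core of compound 3.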